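Adding an Ethylcarbamoyl Group to Compound 2

The compounds below may be only part of what the source reports. "The series", "measured", "known", "first", "only" and "open" are said of these compounds alone.

For the measured compounds named here, in a functional assay on NCI-H460 cells (Homo sapiens) for inhibition, read by sulforhodamine B assay, with a stated time of 72 h (a lower number here means a stronger inhibitor, a higher number a weaker inhibitor), compound 2 `CC(C)c1cc(-n2nncc2-c2ccc(CN3CCCC(O)C3)cc2)c(O)cc1O` gives 45 nM, the only exact number so far. Compound 1 `CC(C)c1cc(-n2cc(-c3ccc(CN4CCN(Cc5ccccc5)CC4)cc3)nn2)c(O)cc1O` gives > 1000 nM, which is a limit of the assay and not a number. Compound 2 therefore has no exact value to be ranked against.

Compound 3 `CCNC(=O)c1nnn(-c2cc(C(C)C)c(O)cc2O)c1-c1ccc(CN2CCCC(O)C2)cc1` keeps the structure of compound 2 except at one place. Ethylcarbamoyl takes the place of hydrogen on an aromatic carbon of the five-membered aromatic ring with 3 nitrogen (ethylcarbamoyl in place of hydrogen on an aromatic carbon). Going by the values given here, no measured pair of compounds shows what this group does, so the expectation rests on the structural change alone and remains uncertain.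

A moderate move towards stronger inhibition is expected in this assay, an estimated step of a 3.0-fold lower number from compound 2 to compound 3 (0.48 log units; beyond the scatter). Compound 3 is expected to give 15 nM, with an estimated range from 3 nM to 80 nM.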

Compound 3, half-maximal inhibitory concentration: 62 nM
Estimate against measurement, compound 3: 4.1-fold (0.62 log units) below; the measured number falls inside the stated range.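

In this assay, placing ethylcarbamoyl on this carbon in place of hydrogen gives a 1.4-fold higher number from compound 2 to compound 3 (0.14 log units; within the scatter), so compound 2 and compound 3 cannot be told apart. For the compounds shown here, this is the first comparison between two exact numbers, and it shows that this aromatic carbon of the five-membered aromatic ring with 3 nitrogen, next to the ring atom that bears a large group, can carry a group of 5 heavy atoms with no change beyond the scatter. Nothing measured here gives a reason for this outcome.

As far as these compounds go, whether other groups would fare the same at this carbon remains open, for example an aminomethyl group, a carboxylic acid or a longer chain such as butylcarbamoyl. A single pair also cannot show whether the amide hydrogen or the ethyl chain of the new group matters, which a comparison with a dimethylcarbamoyl group could begin to address.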